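The source may hold more compounds than are shown below. What is called first, only, known or untested is meant among the compounds shown, and "the series" means these compounds.

Measured so far in an ADME assay on microsomes from liver (Homo sapiens) for metabolic stability, read by LC-MS, using NADPH, with a stated time of 30 min, tested at 0.1 uM; on this read-out lower numbers stand for a less stable compound and higher numbers for a more stable compound:
- compound 1 `O=S(=O)(NCC1COC1)c1cccc(-c2ccc3nccc(-c4ccncc4)c3n2)c1`: 2%
- compound 2 `O=S(=O)(c1cccc(-c2ccc3nccc(-c4ccncc4)c3n2)c1)N1CCC(O)CC1`: 5%
- compound 3 `O=S(=O)(NCCO)c1cccc(Nc2ccc3nccc(-c4ccncc4)c3n2)c1`: 59%

Compound 2, at 5%, lies within the scatter of compound 1 and well under compound 3, which gives 59%. It therefore belongs with the poorly surviving end of this small set.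

Compound 4 `O=S(=O)(c1cccc(-c2ccc3nccc(-c4ccncc4)c3n2)c1)N1CC[C@H](O)C1` departs from compound 2 in one place: 3-hydroxypyrrolidin-1-yl in place of 4-hydroxypiperidin-1-yl on a sulfonyl sulfur. In words, 3-hydroxypyrrolidin-1-yl stands in place of 4-hydroxypiperidin-1-yl on a sulfonyl sulfur.

Among the measured compounds shown here, only one measured step changes the group at this place: a number 3 percentage points higher from compound 1 to compound 2 (within the scatter). That step stayed within the scatter, although the two groups differ considerably. For the measured compounds named here, compound 3 differs from compound 2 in more than one place, so it offers no measured step for this change. The data hold no direct comparison of the two ring sizes.

On the evidence of a number 3 percentage points higher from compound 1 to compound 2 (within the scatter), the expected step in this assay is a number 1 percentage points higher from compound 2 to compound 4 (within the scatter), with no shift beyond the scatter in either direction. Compound 4 is estimated at 6%, within an expected range of 1% to 18%.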

Compound 4, percent of the compound remaining: 17%
The estimate for compound 4 lay 11 percentage points below the measured number, and the stated range covers the measured number.
By their numbers in this assay, from the lowest: compounds 1 and 2 (each within the scatter of the next); then compound 4; then compound 3.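

In this assay the group on the sulfonyl sulfur now makes a measurable difference, with 3-hydroxypyrrolidin-1-yl in place of 4-hydroxypiperidin-1-yl giving a number 12 percentage points higher from compound 2 to compound 4 (beyond the scatter). Replacing ((oxetan-3-yl)methyl)amino with the same group gives a number 15 percentage points higher from compound 1 to compound 4 (beyond the scatter), so this position can respond to the choice of group, although the earlier change here stayed within the scatter and both new steps are modest. Nothing available explains why the five-membered ring gives the higher number.

On these data alone, it remains open whether the step follows the smaller ring or the hydroxyl group, which a plain pyrrolidin-1-yl or a 3-hydroxyazetidin-1-yl on the same sulfonyl sulfur would help to separate. The opposite stereoisomer of 3-hydroxypyrrolidin-1-yl also remains an open question.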